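The source may report more compounds than this note shows. Statements on the series, on what has been measured and on what is new or still open speak of the compounds shown alone.

Of the compounds shown here, three built on one shared core have been tested in an assay on cells for inhibition of Amine oxidase [flavin-containing] A (Homo sapiens), read by Amplex Red, with a stated time of 30 min; a higher number here means a weaker inhibitor, a lower number a stronger inhibitor. Compound 1 `O=C1COC(c2ccc(/N=N/c3ccc(Cl)cc3)cc2)=NN1` carries an azo-linked chlorophenyl arm. In this assay compound 1 gives only a limit, > 100000 nM, and not a number. Compound 2 `Cc1cccc(/C=N/c2ccc(C3=NNC(=O)CO3)cc2)c1` has an imine link to a methylphenyl group. In this assay compound 2 likewise reaches only a limit, > 100000 nM. Compound 3 `O=C1COC(c2ccc(/C=C/c3ccccc3)cc2)=NN1` joins the core to a plain phenyl through a carbon–carbon double bond. In this assay compound 3 also stops at a limit, > 100000 nM, so no number places it. Compound 3 therefore stands exactly where every compound measured here stands: at the limit of > 100000 nM in this assay, at which 3 of the 3 values shown sit, with nothing to rank it against the others.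

Compound 4 `O=C1COC(c2ccc(/C=C/c3ccc(Cl)cc3)cc2)=NN1` has not yet been measured. It differs from compound 3 in one place: chloro in place of hydrogen on an aromatic carbon. Within the data shown here, no step between two measured compounds is available to show what such a change does here. Because compound 1, which also carries a chloro group on its outer ring, gives > 100000 nM, no gain beyond the scatter is expected. The step expected here, a number no higher from compound 3 to compound 4 (the limit leaves the size open), stays within the scatter. Compound 4 is thus estimated at 100000 nM, within a range from 30000 nM to 300000 nM, and most likely again reported only as a limit.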

Compound 4, half-maximal inhibitory concentration: > 100000 nM
Compound 4 was reported as a limit; the forecaster's own chance of this, stated with the estimate: 85%; the middle value lies on the limit itself.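

As far as these compounds go, compound 3 and compound 4 both stop at a limit rather than a number, so no step can be read between them, and the effect of chloro in place of hydrogen stays unknown. The compounds shown leave open which change to the shared core or its arm would give a measurable number in this assay, since all of them share one result: the limit of > 100000 nM in this assay, at which 4 of the 4 values shown sit.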